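The source may hold more compounds than are shown below. What is called first, only, known or untested is meant among the compounds shown, and "the series" means these compounds.

Of the compounds shown here, three built on one shared core have been tested in a functional assay on KG-1 cells (Homo sapiens) for antiproliferative activity; a higher number here means that more compound is needed for the effect, a lower number that less compound is needed. Compound 1 `COCC(C)(C)C#Cc1c(Cl)c2c(Cl)cc(C(N)=O)nc2n1[C@H]1CCCNC1` gives 219 nM. Compound 2 `NC(=O)c1cc(Cl)c2c(Cl)c(C#CCCO)n([C@H]3CCCNC3)c2n1`, which carries a 2-hydroxyethyl group on the triple-bonded carbon, gives 56 nM. Compound 3 `CC(O)C#Cc1c(Cl)c2c(Cl)cc(C(N)=O)nc2n1[C@H]1CCCNC1` gives 147 nM. Among these numbers compound 3 stands second highest of three: the step of a 1.5-fold lower number from compound 1 to compound 3 (0.17 log units; within the scatter) lies within the usual scatter, whereas the step of a 2.6-fold higher number from compound 2 to compound 3 (0.42 log units; beyond the scatter) lies beyond it.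

Compound 4 `CN1CC(C#Cc2c(Cl)c3c(Cl)cc(C(N)=O)nc3n2[C@H]2CCCNC2)CC1=O` has not yet been measured. It differs from compound 3 in one place: 1-methyl-5-oxopyrrolidin-3-yl in place of 1-hydroxyethyl on a triple-bonded carbon. Among the measured compounds shown here, the steps that bear on this change are a 3.9-fold lower number from compound 1 to compound 2 (0.59 log units; beyond the scatter) and a 2.6-fold higher number from compound 2 to compound 3 (0.42 log units; beyond the scatter), which together show that the short hydroxyl-bearing chain of compound 2 gave the lowest number, while the group with more heavy atoms in compound 1 and the branched hydroxyl group in compound 3 both gave higher numbers, these two lying close together. The group entering in compound 4 has more heavy atoms than any of the three and no hydrogen-bond donor, so compound 4 is expected to give a number somewhat higher than compound 3, with an expected step of a 1.8-fold higher number from compound 3 to compound 4 (0.25 log units; within the scatter). The estimate for compound 4 is 260 nM, within a range from 100 nM to 700 nM.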

Compound 4, half-maximal effective concentration: 155 nM
Compound 4: the middle estimate sits 1.7-fold (0.22 log units) above what was measured; the measured number falls inside the stated range.
By their numbers in this assay, from the lowest: compound 2; then compounds 3, 4 and 1 (each within the scatter of the next).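

In this assay, replacing the open-chain 1-hydroxyethyl with the ring-bearing 1-methyl-5-oxopyrrolidin-3-yl on the triple-bonded carbon gives no readable change (a 1.1-fold higher number from compound 3 to compound 4 (0.02 log units; within the scatter)), even though the entering group has more heavy atoms, a five-membered ring and no hydrogen-bond donor. The comparison with the 1-(methoxymethyl)-1-methylethyl group also stays within the scatter (a 1.4-fold lower number from compound 1 to compound 4 (0.15 log units; within the scatter)), whereas the 2-hydroxyethyl group remains apart (a 2.8-fold higher number from compound 2 to compound 4 (0.44 log units; beyond the scatter)), so compound 1, compound 3 and compound 4 form one level, with compound 2 alone giving a lower number. A hydroxyl group alone therefore does not mark out the low number, since compound 3 also carries one yet cannot be told apart from compound 4, and no measurement here explains why the 2-hydroxyethyl group stands apart.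

The compounds shown leave open whether the low number of compound 2 belongs to its hydroxyl group, to its unbranched chain, or to both together. A 2-methoxyethyl group, a 3-hydroxypropyl group or a 2-aminoethyl group on the same triple-bonded carbon would help separate these possibilities.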